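Furan-3-yl for 5-methylfuran-2-yl on an acrylamide chain

The source may hold more compounds than are shown below. What is called first, only, known or untested is meant among the compounds shown, and "the series" means these compounds.

Compounds measured so far in a functional assay on NCI-H460 cells (Homo sapiens) for inhibition, read by MTT assay, with a stated time of 72 h; on this read-out higher numbers stand for weaker inhibition of growth and lower numbers for stronger inhibition of growth:
Compound 1 `N#C/C(=C\c1c(F)c(F)c(F)c(F)c1F)C(=O)c1ccc[nH]1` gives 31000 nM.
Compound 2 `N#C/C(=C\c1ccco1)C(=O)NCc1ccc(Cl)c(Cl)c1` returns a limit of the assay, > 50000 nM.
Compound 3 `COc1ccc(CNC(=O)/C(C#N)=C/c2ccc(C)o2)cc1` also returns a limit of the assay, > 100000 nM.

Compound 3 thus stands at the edge of what this assay can report: its result is a limit and not a number, and it sits at the limit of > 100000 nM in this assay, at which 1 of the 3 values shown sits. Compound 2 sits at the limit of > 50000 nM in this assay, at which 1 of the 3 values shown sits, and only compound 1 carries a numerical value. Nothing can be said about an order among these three beyond that.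

Compound 4 `COc1ccc(CNC(=O)/C(C#N)=C/c2ccoc2)cc1` is the untested neighbour of compound 3. The change is furan-3-yl in place of 5-methylfuran-2-yl on a double-bonded chain carbon bound to a double-bonded chain carbon. With no measured step between any two of these compounds, there is no directly comparable case to set the size of this step. Given that compound 3 gives only a limit at the limit of > 100000 nM in this assay, at which 1 of the 3 values shown sits, the expectation is that the step of a number no higher from compound 3 to compound 4 (the limit leaves the size open) is none beyond the scatter, and that compound 4 most likely remains at or near the limit. The estimate for compound 4 is 100000 nM, with a range from 30000 nM to 300000 nM.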

Compound 4, concentration for 50% growth inhibition: 8000 nM
For compound 4 the middle estimate is 13-fold (1.10 log units) above the measured one; measured number below the stated range.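

In this assay, furan-3-yl in place of 5-methylfuran-2-yl gives an at least 12-fold lower number from compound 3 to compound 4 (1.09 log units; beyond the scatter), the first step measured between two compounds that differ in one place. It shows that the group on a double-bonded chain carbon bound to a double-bonded chain carbon is not indifferent, even though both groups are five-membered aromatic rings with one hetero atom and the count of hydrogen-bond donors and acceptors stays the same. The size of the step remains open on one side, as compound 3 gives a limit of the assay and not a number: the limit of > 100000 nM in this assay, at which 1 of the 4 values shown sits.

The compounds shown leave open whether the step belongs to the loss of the methyl group or to the change from a furan-2-yl to a furan-3-yl attachment, as this one change holds both at once. They also leave open how a thiophen-3-yl or pyridin-3-yl group would read at this place, and whether a methyl group, an amine or a carboxylic acid on the furan-3-yl ring would keep the value of compound 4 at 8000 nM.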